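From Compound 3 to Compound 4: One Group Exchanged

A few compounds are considered here, and "the series" means these few. Any claim that something is new, unique, unknown or untested is made for them only; others in the source may bear on it.

In a functional assay on HepG2 cells (Homo sapiens) for antiproliferative activity, read by MTT assay, with a stated time of 72 h (a lower number here means a stronger inhibitor, a higher number a weaker inhibitor), compound 1 (`COc1cc2c(Nc3ccc(C#N)cc3)ncnc2cc1OCCCN(C)C`) gives > 100000 nM which is a limit and not a number. Compound 2 (`COc1cc2c(Nc3ccc(C#N)cc3)ncnc2cc1OCCCN1CCCC1`) gives 20900 nM and compound 3 (`CCOC(=O)C1CCN(CCCOc2cc3ncnc(Nc4ccc(C#N)cc4)c3cc2OC)CC1`) gives 57700 nM so compound 3 holds the higher, weaker of the two true numbers. Compound 4 (`COc1cc2c(Nc3ccc(C#N)cc3)ncnc2cc1OCCCN1CCN(C)CC1`) puts 4-methylpiperazin-1-yl in place of 4-(ethoxycarbonyl)piperidin-1-yl on the same saturated chain carbon (4-methylpiperazin-1-yl in place of 4-(ethoxycarbonyl)piperidin-1-yl on a saturated chain carbon, three bonds along the chain from an oxygen on an aromatic ring). Earlier swaps of this group were modest in size: a 2.8-fold higher number from compound 2 to compound 3 (0.44 log units; beyond the scatter) and an at least 4.7-fold lower number from compound 1 to compound 2 (0.67 log units; beyond the scatter) while an at least 1.7-fold lower number from compound 1 to compound 3 (0.23 log units; that floor lies within the scatter) has a floor within the scatter. These modest sizes lead to an expected 1.4-fold lower number from compound 3 to compound 4 (0.16 log units; within the scatter) in this assay which would stay within the scatter. The estimate for compound 4 is 40000 nM with 13000 nM to 100000 nM as the expected range.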

Compound 4, half-maximal inhibitory concentration: 13800 nM
Beside the measured number, compound 4's estimate is 2.9-fold (0.46 log units) above it; the measured number falls inside the stated range.
By their numbers in this assay, from the lowest: compounds 4 and 2 (each within the scatter of the next); then compound 3. At a limit, above all of these: compound 1.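

In this assay, exchanging 4-(ethoxycarbonyl)piperidin-1-yl for 4-methylpiperazin-1-yl gives a 4.2-fold lower number from compound 3 to compound 4 (0.62 log units; beyond the scatter), so this end of the chain tolerates more change in the number than the earlier true values alone showed. The new six-membered ring and the five-membered ring of compound 2 cannot be told apart here: a 1.5-fold lower number from compound 2 to compound 4 (0.18 log units; within the scatter). Compound 1 has a limit and not a number, so its step is only a floor: an at least 7.2-fold lower number from compound 1 to compound 4 (0.86 log units; beyond the scatter).

Open, on these data alone, is whether a plain piperidin-1-yl ring without the ester, or a morpholin-4-yl ring, would match compound 2 and compound 4. Also open, as far as these compounds go, is how a longer chain carrying 4-methylpiperazin-1-yl would read.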